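Bromo to iodo on the shared core

A few compounds are considered here, and "the series" means these few. Any claim that something is new, unique, unknown or untested is made for them only; others in the source may bear on it.

Measured in a functional assay on NCI-H522 cells (Homo sapiens) for cytotoxicity, with a stated time of 3 days; on this read-out higher numbers stand for weaker inhibition and lower numbers for stronger inhibition:
compound 1 `C=Cc1nc2ccccc2[se]1` gives 12200 nM
compound 2 `C#Cc1nc2ccccc2[se]1` gives 2170 nM
compound 3 `Brc1nc2ccccc2[se]1` gives > 40000 nM
compound 4 `Ic1nc2ccccc2[se]1` is not yet measured

The entry for compound 3 is a limit, not a number. The change to compound 4 is iodo in place of bromo on an aromatic carbon, next to the ring nitrogen and next to the ring selenium. Going by the values given here, no measured step exchanges one halogen for another. The nearest are the two that bring in bromo, an at least 3.2-fold higher number from compound 1 to compound 3 (0.51 log units; beyond the scatter) and an at least 18-fold higher number from compound 2 to compound 3 (1.26 log units; beyond the scatter). Both lost ground, while a 5.6-fold lower number from compound 1 to compound 2 (0.75 log units; beyond the scatter) is the only gain. No step beyond the scatter is expected in this assay, in either direction. The expected step is a number no higher from compound 3 to compound 4 (the limit leaves the size open). For compound 4 the estimate is 40000 nM, with an expected range from 15000 nM to 90000 nM.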

Compound 4, half-maximal inhibitory concentration: > 40000 nM
Compound 4: a limit, no number; the forecaster's own chance of this, stated with the estimate: 60%; the middle value sits exactly at the limit.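

In this assay, iodo on this aromatic carbon loses ground just as bromo does: an at least 18-fold higher number from compound 2 to compound 4 (1.26 log units; beyond the scatter) and an at least 3.2-fold higher number from compound 1 to compound 4 (0.51 log units; beyond the scatter). Neither halogen now matches vinyl or ethynyl at this position, next to the ring nitrogen and next to the ring selenium. The step between the two halogens cannot be read because both sit at the same limit: the limit of > 40000 nM in this assay, at which 2 of the 4 values shown sit.

Open, on these data alone, is whether any order exists between bromo and iodo in this assay. Also open, as far as these compounds go, is how an amine or a longer alkyne chain on this carbon would compare with compound 2 at 2170 nM.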